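Removing the meta fluorine from the benzylamide of compound 3

The source may report more compounds than this note shows. Statements on the series, on what has been measured and on what is new or still open speak of the compounds shown alone.

In a functional assay on MDA-MB-231 cells (Homo sapiens) for inhibition, read by MTT assay (a higher number here means a weaker inhibitor of growth, a lower number a stronger inhibitor of growth), compound 1 `CC1=C(/C=C/C(C)=C/C=C/C(C)=C\C(=O)NCc2ccc(F)cc2)C(C)(C)CCC1n1ccnc1` gives 1410 nM, compound 2 `CC1=C(/C=C/C(C)=C/C=C/C(C)=C\C(=O)Nc2ccccc2)C(C)(C)CCC1n1ccnc1` gives 1740 nM, and compound 3 `CC1=C(/C=C/C(C)=C/C=C/C(C)=C\C(=O)NCc2cccc(F)c2)C(C)(C)CCC1n1ccnc1` gives 1650 nM. Compound 3 sits close to its neighbours: a 1.1-fold lower number from compound 2 to compound 3 (0.02 log units; within the scatter), and a 1.2-fold higher number from compound 1 to compound 3 (0.07 log units; within the scatter). The unmeasured compound 4 `CC1=C(/C=C/C(C)=C/C=C/C(C)=C\C(=O)NCc2ccccc2)C(C)(C)CCC1n1ccnc1` differs from compound 3 by hydrogen in place of fluoro on an aromatic carbon. For the measured compounds named here, no measured step removes a fluorine outright; the steps that bear on the amide-side aryl are a 1.2-fold higher number from compound 1 to compound 3 (0.07 log units; within the scatter), a 1.2-fold higher number from compound 1 to compound 2 (0.09 log units; within the scatter) and a 1.1-fold lower number from compound 2 to compound 3 (0.02 log units; within the scatter), all within the scatter, so no step beyond the scatter is expected in this assay. Compound 4 is therefore estimated at 1600 nM, with a range of 800 nM to 3200 nM, which means an expected 1.0-fold lower number from compound 3 to compound 4 (0.01 log units; within the scatter).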

Compound 4, concentration for 50% growth inhibition: 5880 nM
Beside the measured number, compound 4's estimate is 3.7-fold (0.57 log units) below it; the whole stated range lies below it.
By their numbers in this assay, from the lowest: compounds 1, 3 and 2 (each within the scatter of the next); then compound 4.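

Working in this assay, the fluorine turns out to matter where the earlier steps suggested nothing: hydrogen in place of fluoro gives a clear loss against both fluorinated benzylamides (a 3.6-fold higher number from compound 3 to compound 4 (0.55 log units; beyond the scatter); a 4.2-fold higher number from compound 1 to compound 4 (0.62 log units; beyond the scatter)). The plain benzyl group also stands apart from the phenyl amide (a 3.4-fold higher number from compound 2 to compound 4 (0.53 log units; beyond the scatter)), although compound 3 and compound 1 stay within the scatter of that phenyl amide. At this position, then, the benzyl group keeps the activity of the series only with a fluorine on its ring.

Nothing available bears on why this is so. On these data alone, whether chloro, methoxy or a longer chain between the amide nitrogen and the ring would match fluoro remains open.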